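Trimming the Hydrazone Aryl Group Down to Plain Phenyl

The source may hold more compounds than are shown below. What is called first, only, known or untested is meant among the compounds shown, and "the series" means these compounds.

The measured compounds:
Compound 1, `Cc1c(C(=O)N/N=C\c2ccc(O)cc2)oc2cccc(O)c12`, gives 21700 nM.
Compound 2, `Cc1c(C(=O)N/N=C\c2c(O)cccc2Cl)oc2cccc(O)c12`, gives 18700 nM.
Compound 3, `Cc1c(C(=O)N/N=C\c2ccco2)oc2cccc(O)c12`, gives >= 40000 nM, which is a limit of the assay rather than a number.

In a functional assay on PC-3 cells (Homo sapiens) for inhibition (a lower number here means a stronger inhibitor, a higher number a weaker inhibitor), compound 2 holds the lowest of the two numbers, and compound 1 sits nearest to it: a 1.2-fold lower number from compound 1 to compound 2 (0.06 log units; within the scatter). Compound 3 is reported only as a limit (the limit of >= 40000 nM in this assay, at which 1 of the 3 values shown sits). The unmeasured compound 4, `Cc1c(C(=O)N/N=C\c2ccccc2)oc2cccc(O)c12`, differs from compound 2 thus: phenyl in place of 2-chloro-6-hydroxyphenyl on a carbon with a double bond to nitrogen.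

Among the measured compounds shown here, two measured steps touch this carbon. The step of a 1.2-fold lower number from compound 1 to compound 2 (0.06 log units; within the scatter) exchanged one hydroxyphenyl for another and did not move the number beyond the scatter. The step of an at least 2.1-fold higher number from compound 2 to compound 3 (0.33 log units; beyond the scatter) replaced the aryl ring with furan-2-yl and raised the number by at least a modest amount. Plain phenyl keeps the six-membered carbon ring that furan-2-yl lacks, so the change from compound 2 to compound 4 is expected to be small, with perhaps a slightly higher number, as a 1.3-fold higher number from compound 2 to compound 4 (0.13 log units; within the scatter). Compound 4 is therefore estimated at 25000 nM, within 11000 nM to 45000 nM.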

Compound 4, half-maximal inhibitory concentration: 29200 nM
Estimate against measurement, compound 4: 1.2-fold (0.07 log units) below; low and high end bracket the measured number.
By their numbers in this assay, from the lowest: compounds 2, 1 and 4 (each within the scatter of the next). At a limit, above all of these: compound 3.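

In this assay, plain phenyl stays within the scatter of both hydroxylated rings: a 1.6-fold higher number from compound 2 to compound 4 (0.19 log units; within the scatter) shows the loss of the chlorine and the hydroxy together, and a 1.3-fold higher number from compound 1 to compound 4 (0.13 log units; within the scatter) shows the loss of the single hydroxy. On this carbon, then, a six-membered aromatic ring with no hydrogen-bond donor or acceptor gives a number not separable from those of the rings that carry one of each. The step of an at least 1.3-fold lower number from compound 3 to compound 4 (0.13 log units; that floor lies within the scatter) is only a floor, set by a limit of the assay for compound 3, and that floor does not separate phenyl from furan-2-yl: the limit of >= 40000 nM in this assay, at which 1 of the 4 values shown sits.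

Going by these compounds, it remains open whether an amine or a carboxylic acid on the phenyl ring would move the number beyond the scatter. Also open, on these data alone, is whether a saturated ring such as cyclohexyl would serve in place of phenyl.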